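Swapping a Decyl Chain for a Difluorophenyl Ring

A few compounds are considered here, and "the series" means these few. Any claim that something is new, unique, unknown or untested is made for them only; others in the source may bear on it.

Three compounds share one core and differ only in the group carried on the five-membered ring with three nitrogens. Compound 3 `CCCCCCCCCCc1cn(C[C@H](O)[C@H]2OC(=O)C(OCc3ccccc3)=C2OCc2ccccc2)nn1` carries a decyl chain and gives the lowest number of the three in a functional assay on MCF7 cells (Homo sapiens) for antiproliferative activity, read by MTT assay, with a stated time of 72 h; a lower number here means a stronger inhibitor, a higher number a weaker inhibitor: compound 3 reaches 80 nM. Compound 1 `O=C1O[C@H]([C@@H](O)Cn2cc(-c3cc(C(F)(F)F)cc(C(F)(F)F)c3)nn2)C(OCc2ccccc2)=C1OCc1ccccc1` carries a phenyl ring bearing two trifluoromethyl groups, and in this assay compound 1 gives 45900 nM, far above compound 3. Compound 2 `O=C1O[C@H]([C@@H](O)Cn2cc(-c3cccc(O)c3)nn2)C(OCc2ccccc2)=C1OCc1ccccc1` carries a hydroxyphenyl ring, and in this assay compound 2 gives 51800 nM. Among the measured compounds shown here, the one measured single-change step runs a 650-fold lower number from compound 2 to compound 3 (2.81 log units; beyond the scatter), so trading an aromatic ring for the chain lowered the number greatly.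

Compound 4 `O=C1O[C@H]([C@@H](O)Cn2cc(-c3cc(F)cc(F)c3)nn2)C(OCc2ccccc2)=C1OCc1ccccc1` reverses that direction: 3,5-difluorophenyl in place of decyl on an aromatic carbon. Both ring-bearing compounds sit far above compound 3, and the step of a 650-fold lower number from compound 2 to compound 3 (2.81 log units; beyond the scatter) is the closest guide, pointing to a rise of similar size. Compound 4 is therefore expected to show a 560-fold higher number from compound 3 to compound 4 (2.75 log units; beyond the scatter). Compound 4 is estimated at 45000 nM in this assay, with a range from 15000 nM to 120000 nM.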

Compound 4, half-maximal inhibitory concentration: 27700 nM
Compound 4: the middle estimate sits 1.6-fold (0.21 log units) above what was measured, within the range that was stated.
By their numbers in this assay, from the lowest: compound 3; then compounds 4, 1 and 2 (each within the scatter of the next).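

In this assay, the exchange of chain for ring now has a second measured example, a 350-fold higher number from compound 3 to compound 4 (2.54 log units; beyond the scatter), so the large gap seen with the hydroxyphenyl ring also appears with a ring carrying two fluorines and no hydroxyl group. Exchanging one ring for the other gives a 1.9-fold lower number from compound 2 to compound 4 (0.27 log units; within the scatter), so at this aromatic carbon the choice between 3,5-difluorophenyl and 3-hydroxyphenyl counts for far less than the choice between either ring and decyl. Nothing measured here gives a reason for the gap between chain and rings.

As far as these compounds go, how much of the decyl chain is needed remains open, and a shorter hexyl chain or a longer dodecyl chain would help to show this. It is also unknown whether a chain ending in an amine or a carboxylic acid would keep the low number of compound 3.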